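Fluoro in place of methyl in compound 2

A few compounds are considered here, and "the series" means these few. Any claim that something is new, unique, unknown or untested is made for them only; others in the source may bear on it.

Values so far, all from an ADME assay on J774 cells (Mus musculus) for antiproliferative activity, with a stated time of 72 h; on this read-out lower numbers stand for an effect already at smaller amounts and higher numbers for an effect only at larger amounts of compound
- compound 1 `CCCCc1cc2c(=O)cc(C)[nH]c2cc1OCCOc1ccccc1` gives 28000 nM
- compound 2 `CCCCc1cc2c(=O)c(-c3ccc(C(F)(F)F)cc3C)c(C)[nH]c2cc1OCCOc1ccccc1` gives 20000 nM

Compound 2 stands within the scatter of compound 1, so the two values give no order. Compound 3 `CCCCc1cc2c(=O)c(-c3ccc(C(F)(F)F)cc3F)c(C)[nH]c2cc1OCCOc1ccccc1` is still to be measured in this assay and differs from compound 2 by fluoro in place of methyl on an aromatic carbon (fluoro in place of methyl on an aromatic carbon, ortho to a large group and meta to a trifluoromethyl group). Among the compounds with values here, no measured pair isolates this exchange. Within the data shown here, the nearest evidence is the one step available, where 2-methyl-4-(trifluoromethyl)phenyl in place of hydrogen on an aromatic carbon gave a 1.4-fold lower number from compound 1 to compound 2 (0.15 log units; within the scatter) and so did not move the number beyond the scatter. On the strength of that step, the exchange in compound 3 is expected to give no step beyond the scatter in this assay with neither direction favoured. The expected change is a 1.1-fold higher number from compound 2 to compound 3 (0.04 log units; within the scatter) and remains an estimate until measured. Compound 3 is expected at 22000 nM (estimated range 10000 nM to 48000 nM).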

Compound 3, half-maximal effective concentration: 19000 nM
Compound 3: the middle estimate sits 1.2-fold (0.06 log units) above what was measured; low and high end bracket the measured number.
By their numbers in this assay, from the lowest: compounds 3, 2 and 1 (each within the scatter of the next).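

In this assay, fluoro in place of methyl on this aromatic carbon, ortho to a large group and meta to a trifluoromethyl group, gave a 1.1-fold lower number from compound 2 to compound 3 (0.02 log units; within the scatter), so the two substituents cannot be told apart at this position on this read-out. The fluoro-bearing group also behaves like the methyl-bearing one when set against hydrogen on the shared core: putting it in place of that hydrogen gave a 1.5-fold lower number from compound 1 to compound 3 (0.17 log units; within the scatter), so neither substituted phenyl group has yet moved the number beyond the scatter. Nothing measured alongside these values speaks to the reason for this result.

Open, from the compounds shown here alone, is whether this aromatic carbon responds at all to an exchange more drastic than methyl to fluoro, such as an amine or a carboxylic acid in the same place. Equally open, going by these compounds, is whether the trifluoromethyl group matters to the number, since both compounds with the substituted phenyl group carry it, and whether a nitrile in its place would read any differently.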